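Bromo to iodo swap at the para position of the aryl ring

The source may report more compounds than this note shows. Statements on the series, on what has been measured and on what is new or still open speak of the compounds shown alone.

Compound 1 `O=C(CCCCCc1cccc(Br)c1)N1CCOC1=O`, compound 2 `O=C(CCCCCc1cccc(I)c1)N1CCOC1=O` and compound 3 `O=C(CCCCCc1ccc(Br)cc1)N1CCOC1=O` have been measured in an assay on HEK293 cells for inhibition of N-acylethanolamine-hydrolyzing acid amidase (Rattus norvegicus), read by LC-MS, with a stated time of 30 min; on this read-out lower numbers stand for stronger inhibition and higher numbers for weaker inhibition. Compound 1 gives 430 nM, compound 2 gives 3120 nM and compound 3 gives 8510 nM. Compound 2 differs from compound 1 by iodo in place of bromo on an aromatic carbon, and this step gave a 7.3-fold higher number from compound 1 to compound 2 (0.86 log units; beyond the scatter). Compound 3 and compound 1 contain the same atoms joined differently; the difference between the two cores is not broken down here.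

Compound 4 `O=C(CCCCCc1ccc(I)cc1)N1CCOC1=O` has not yet been measured. It differs from compound 3 by iodo in place of bromo on an aromatic carbon. This is the same kind of change as that made in compound 2, but the place is not the same: in compound 2 the iodo sits meta to a large group, whereas in compound 4 it sits para to a large group. In this assay a step of a 4.1-fold higher number from compound 3 to compound 4 (0.61 log units; beyond the scatter) is expected, because compound 1 and compound 2 showed a 7.3-fold higher number from compound 1 to compound 2 (0.86 log units; beyond the scatter), although the differing place leaves the size uncertain. Compound 4 is thus estimated at 35000 nM, between 10000 nM and 120000 nM.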

Compound 4, half-maximal inhibitory concentration: > 20000 nM
Compound 4 ended at the assay's limit (the forecaster's own chance of this, stated with the estimate: 30%); the middle value lies beyond the limit too.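

In this assay, iodo in place of bromo on an aromatic carbon moves the number in the same direction, towards weaker inhibition, on both cores: an at least 2.3-fold higher number from compound 3 to compound 4 (0.37 log units; beyond the scatter) stands alongside a 7.3-fold higher number from compound 1 to compound 2 (0.86 log units; beyond the scatter). Compound 4 reads > 20000 nM, which is a limit of the assay and not a number. The direction of the change therefore carries from the core of compound 1 to the core of compound 3, but equal size on the two cores cannot be claimed, and two cores do not establish a rule for the wider series: the same change on two cores in this assay, a 7.3-fold higher number (0.86 log units; beyond the scatter) from compound 1 to compound 2 and an at least 2.3-fold higher number (0.37 log units; beyond the scatter) from compound 3 to compound 4; the limit leaves it open whether they differ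

As far as these compounds go, it remains open whether chloro or fluoro on the same aromatic carbon would follow the same direction as the step from bromo to iodo. From the compounds shown here alone, it is also open whether the step would keep its direction with a longer chain in place of the present one, or with an amine or a carboxylic acid on the aromatic ring.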